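The compounds below may be only part of what the source reports. "The series", "measured", "known", "first", "only" and "open" are said of these compounds alone.

In a functional assay on MCF7 cells (Homo sapiens) for antiproliferative activity, read by MTT assay, with a stated time of 72 h (on this read-out higher numbers stand for weaker inhibition and lower numbers for stronger inhibition), compound 1 (`O=C1COc2ccc(-c3cccc(NS(=O)(=O)c4ccc(F)cc4)c3)cc2N1`) gives 18300 nM as the higher of the two true numbers. Compound 3 (`COc1ncc(-c2ccc3c(c2)N(c2ccccc2)C(=O)CO3)cc1NS(=O)(=O)c1ccc(F)cc1`) gives 8870 nM and lies beyond the scatter on the lower side of compound 1. Compound 2 (`COc1cccc(N2C(=O)COc3ccc(-c4cnc(OC)c(NS(=O)(=O)c5ccc(F)cc5)c4)cc32)c1`) reads > 40000 nM and this is a limit of the assay, not a number.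

Within the data shown here, the change to compound 4 (`O=C1COc2ccc(-c3cccc(NS(=O)(=O)c4ccc(F)cc4)c3)cc2N1c1ccc(Cl)cc1`) is 4-chlorophenyl in place of hydrogen on an amide-type nitrogen in a ring and no measured step makes this change directly. Among the measured compounds shown here, the one measured step, an at least 4.5-fold lower number from compound 2 to compound 3 (0.65 log units; beyond the scatter) for hydrogen in place of methoxy on an aromatic carbon, concerns another group. Still, compounds 2 and 3 both carry an aromatic ring on that nitrogen, and they fall on opposite sides of compound 1. Compound 3 at 8870 nM is the closer guide, though it also differs from compound 4 elsewhere.

A small step to a lower number is therefore expected in this assay with a wide range, and compound 2 stands against that direction. The expected step is a 2.0-fold lower number from compound 1 to compound 4 (0.31 log units; beyond the scatter) in this estimate. Compound 4 is estimated at 9000 nM and expected between 3000 nM and 30000 nM in the next measurement.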

Compound 4, half-maximal inhibitory concentration: 39800 nM
Compound 4: the middle estimate sits 4.4-fold (0.65 log units) below what was measured; the whole stated range lies below it.
By their numbers in this assay, from the lowest: compound 3; then compound 1; then compound 4. At a limit, above all of these: compound 2.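

In this assay, the amide-type nitrogen in a ring now has a direct reading: a 2.2-fold higher number from compound 1 to compound 4 (0.34 log units; beyond the scatter). The earlier compounds shown here carried an aromatic ring on that nitrogen only alongside other differences, so they gave no step for this change; on the core of compound 1, 4-chlorophenyl in place of hydrogen modestly weakens inhibition. Compound 2 is a limit and not a number, so no step upward from this level can be sized against it: the limit of > 40000 nM in this assay, at which 1 of the 4 values shown sits.

Going by these compounds, whether the weakening belongs to the chlorine or to the phenyl ring itself stays open: an unsubstituted phenyl on this nitrogen appears only in compound 3, on a different core. On these data alone, how a methyl group or an aminoethyl chain on that nitrogen would read in this assay also stays open.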